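Triazole nitrogen substituent and cytotoxic potency in Huh-7 cells

The source may report more compounds than this note shows. Statements on the series, on what has been measured and on what is new or still open speak of the compounds shown alone.

Measured so far:
- compound 1 `Cc1ccc(-n2cc(COc3cccc4cnc(Nc5cccc(Cl)c5)nc34)nn2)c([N+](=O)[O-])c1`: 25000 nM
- compound 2 `Clc1cccc(Nc2ncc3cccc(OCc4cn(-c5cc(Cl)cc(Cl)c5)nn4)c3n2)c1`: 7000 nM
- compound 3 `Clc1cccc(Nc2ncc3cccc(OCc4cn(Cc5c(Cl)cccc5Cl)nn4)c3n2)c1`: 7000 nM

In a functional assay on Huh-7 cells (Homo sapiens) for cytotoxicity, read by cell counting, with a stated time of 48 h (on this read-out lower numbers stand for stronger inhibition and higher numbers for weaker inhibition), compound 1 gives 25000 nM, the highest of the three numbers, so the weakest inhibition seen in the set so far. Both measured steps away from compound 1 point the same way: a 3.6-fold lower number from compound 1 to compound 2 (0.55 log units; beyond the scatter) and a 3.6-fold lower number from compound 1 to compound 3 (0.55 log units; beyond the scatter). Between compound 2 and compound 3 there is no change at the digits printed from compound 2 to compound 3 (within the scatter), so the two dichloro-bearing groups are not separable on these numbers.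

Compound 4 `Clc1ccc(-n2cc(COc3cccc4cnc(Nc5cccc(Cl)c5)nc34)nn2)cc1` is not yet measured. It differs from compound 1 only at the aromatic nitrogen of the five-membered ring: 4-chlorophenyl in place of 4-methyl-2-nitrophenyl on an aromatic nitrogen. The relevant precedents are the two steps from compound 1, in which the 4-methyl-2-nitrophenyl was exchanged for a chlorine-bearing aryl or benzyl group and the number fell modestly and beyond the scatter. For the measured compounds named here, the 4-chlorophenyl carries a single chlorine, with no measured compound that isolates that feature, so a step of similar or slightly smaller size toward a lower number is expected in this assay.

Estimated step: a 2.5-fold lower number from compound 1 to compound 4 (0.40 log units; beyond the scatter), with the value for compound 4 expected at 10000 nM (range 4000 nM to 25000 nM).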

Compound 4, half-maximal inhibitory concentration: 24000 nM
Estimate against measurement, compound 4: 2.4-fold (0.38 log units) below; measured number inside the range.
By their numbers in this assay, from the lowest: compounds 2 and 3 (each within the scatter of the next); then compounds 4 and 1 (each within the scatter of the next).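

In this assay the 4-chlorophenyl in place of 4-methyl-2-nitrophenyl gives a 1.0-fold lower number from compound 1 to compound 4 (0.02 log units; within the scatter), so the presence of chlorine on the aryl group does not by itself carry the fall seen for the dichloro-bearing groups. Set against those groups, the 4-chlorophenyl gives both a 3.4-fold higher number from compound 2 to compound 4 (0.54 log units; beyond the scatter) and a 3.4-fold higher number from compound 3 to compound 4 (0.54 log units; beyond the scatter), which places the difference at this position on the aromatic nitrogen between the two dichloro-bearing groups on one side and the 4-chlorophenyl and 4-methyl-2-nitrophenyl on the other. No supporting measurement is available to explain this split.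

The compounds shown leave open whether the lower numbers follow the dichloro pattern itself or the placement of the chlorines, and a 3-chlorophenyl or 3,4-dichlorophenyl group would test that directly. Also open, from the compounds shown here alone, is whether the methyl and nitro groups of compound 1 each matter on their own, and how an unsubstituted phenyl, a 4-aminophenyl, a 4-carboxyphenyl or a longer alkyl chain on this nitrogen would compare.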